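Swapping 1-Hydroxyethyl for a Methylthiazole

The source may hold more compounds than are shown below. What is called first, only, known or untested is meant among the compounds shown, and "the series" means these compounds.

Two compounds carry numbers in an in vivo ADME assay on the whole organism (strain 129/SvEvBrd x C57BL/6) for pharmacokinetics, with Mus musculus as the target (on this read-out lower numbers stand for lower oral bioavailability and higher numbers for higher oral bioavailability), so far. Compound 1 (`CC(=O)c1nc([C@@H](O)[C@H](O)[C@H](O)CO)c(-c2ccccc2)[nH]1`) reaches 49.6% on this read-out. Compound 2 (`CC(O)c1nc([C@@H](O)[C@H](O)[C@H](O)CO)c[nH]1`) reaches 22% and so stands as the lower of the two, with compound 1 above it by more than the usual scatter. In compound 3 (`Cc1nc(-c2nc([C@@H](O)[C@H](O)[C@H](O)CO)c[nH]2)cs1`), still unmeasured, 2-methyl-1,3-thiazol-4-yl stands in place of the 1-hydroxyethyl of compound 2 on an aromatic carbon between two ring nitrogen atoms (2-methyl-1,3-thiazol-4-yl in place of 1-hydroxyethyl on an aromatic carbon). Among the measured compounds shown here, no measured pair differs in one place only, so nothing yet shows directly what such an exchange does in this assay for this series. For the measured compounds named here, a modest rise, close to the edge of the scatter, is expected, as compound 2 at 22% is the lower of only two numbers and compound 1 at 49.6% is the sole higher reference. The estimated change is a number 10 percentage points higher from compound 2 to compound 3 (within the scatter) and it remains tentative. For compound 3 the estimate is 32% with an expected range from 12% to 55% on repeated measurement.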

Compound 3, oral bioavailability: 23%
Estimate against measurement, compound 3: 9 percentage points above; the range from low to high includes it.
By their numbers in this assay, from the lowest: compounds 2 and 3 (each within the scatter of the next); then compound 1.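

In this assay, among the compounds shown here, the exchange of 1-hydroxyethyl for 2-methyl-1,3-thiazol-4-yl on an aromatic carbon, between two ring nitrogen atoms, reads as a number 1 percentage points higher from compound 2 to compound 3 (within the scatter), and this is the first direct reading of any single exchange. At this place, a group of 3 heavy atoms with no ring and 1 hydrogen-bond donor and a group of 6 heavy atoms with a five-membered aromatic ring and 0 hydrogen-bond donors thus give oral bioavailability values within the scatter of each other, so this one exchange shows no measurable effect on the read-out. Nothing in the data accounts for how close the two numbers lie.

From the compounds shown here alone, it remains open whether another kind of group at this place, such as an amine, a carboxylic acid or a longer alkyl chain, would give a step beyond the scatter. Going by these compounds, it is equally open whether the same exchange would read the same way on a core that also carries a phenyl group, as the core of compound 1 does.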